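A Methoxy Group Added Where Two Already Sit

The source may report more compounds than this note shows. Statements on the series, on what has been measured and on what is new or still open speak of the compounds shown alone.

Three compounds built on one shared core were tested in a functional assay on A549 cells (Homo sapiens) for cytotoxicity, read by MTT assay, with a stated time of 72 h; a lower number here means a stronger inhibitor, a higher number a weaker inhibitor. Compound 1 `COc1ccc(S(=O)(=O)c2nc3ccccc3nc2Nc2ccccc2)cc1` gives 13200 nM in this assay. Compound 2 `COc1ccc(Nc2nc3ccccc3nc2S(=O)(=O)c2ccc(OC)cc2)cc1` differs from compound 1 by methoxy in place of hydrogen on an aromatic carbon, and in this assay compound 2 gives 8260 nM, a step of a 1.6-fold lower number from compound 1 to compound 2 (0.20 log units; within the scatter). Compound 3 `COc1cc(Nc2nc3ccccc3nc2S(=O)(=O)c2ccc(Br)cc2)cc(OC)c1` gives 15900 nM in this assay; how its core differs from the core of compound 1 is not broken down here, and the gap between the two values stays within the scatter.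

Compound 4 `COc1cc(Nc2nc3ccccc3nc2S(=O)(=O)c2ccc(Br)cc2)cc(OC)c1OC` has not yet been measured. It differs from compound 3 by methoxy in place of hydrogen on an aromatic carbon. Among the compounds with values here, this is the same kind of change as the one from compound 1 to compound 2, but not the same change: in compound 1 the place is para to a large group, while in compound 3 it is para to a large group and also ortho to two methoxy groups. Because the earlier step of a 1.6-fold lower number from compound 1 to compound 2 (0.20 log units; within the scatter) stayed within the scatter, the step of a 1.4-fold lower number from compound 3 to compound 4 (0.16 log units; within the scatter) is expected to be similarly small. Compound 4 is therefore estimated to give 11000 nM in this assay, most likely between 5500 nM and 25000 nM.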

Compound 4, half-maximal inhibitory concentration: 6110 nM
For compound 4 the middle estimate is 1.8-fold (0.26 log units) above the measured one, and the stated range covers the measured number.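

On the core of the later pair, methoxy in place of hydrogen gives a 2.6-fold lower number from compound 3 to compound 4 (0.42 log units; beyond the scatter) in this assay. Set beside the earlier step, this does not show that the change behaves differently on the two cores: the same change on two cores in this assay, a 1.6-fold lower number (0.20 log units; within the scatter) from compound 1 to compound 2 and a 2.6-fold lower number (0.42 log units; beyond the scatter) from compound 3 to compound 4, 1.6-fold (0.21 log units) apart, within the scatter of two such steps. The result fits the change carrying over from one core to the other in this series, but it does not prove it, since the earlier step alone cannot be told from scatter and two pairs cannot give a rule for other cores.

The compounds shown leave open whether a different group at this place, such as an amine or a longer chain like ethoxy, would give a step of similar size. They also leave open whether methoxy would give a similar step on a core carrying a carboxylic acid.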